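Methoxymethyl on the free hydroxy of compound 3

A few compounds are considered here, and "the series" means these few. Any claim that something is new, unique, unknown or untested is made for them only; others in the source may bear on it.

Compound 3 (`CCCC/C=C\CCCCCCCCCc1cc(=O)c2c(O)c(C)c(O)c(C)c2o1`) sits at the weak end of a functional assay on MDA-MB-231 cells (Homo sapiens) for antiproliferative activity, read by MTT assay; a higher number here means a weaker inhibitor, a lower number a stronger inhibitor. Compound 3 gives > 87000 nM, which is a limit and not a number. Compound 2 (`CC/C=C\C/C=C\C/C=C\CCCCCCCc1cc(=O)c2c(O)c(C)c(O)c(C)c2o1`), in contrast, gives a measured 6790 nM. The picture so far is the limit of > 87000 nM in this assay, at which 2 of the 3 values shown sit.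

Compound 4 (`CCCC/C=C\CCCCCCCCCc1cc(=O)c2c(O)c(C)c(OCOC)c(C)c2o1`) follows from compound 3 by one change: methoxymethyl in place of hydrogen on an oxygen on an aromatic ring, that is, hydroxy to methoxymethoxy. Within the data shown here, the only measured step is an at least 12-fold higher number from compound 2 to compound 3 (1.10 log units; beyond the scatter). That step is large, but it lies in the chain and not at this oxygen, so it gives no direct size for the new change. The closest evidence is compound 1 (`CCCC/C=C\CCCCCCCCCc1cc(=O)c2c(O)c(C)c(OCOC)cc2o1`), which also carries methoxymethoxy on a long unsaturated chain. Compound 1 gives > 87000 nM, which is also a limit.

Compound 3 has no number to fall from, and compound 1 shows no measurable activity with this group, so no measurable gain is expected in this assay, and most likely compound 4 will again be reported only as a limit. The expected change is a step that the limit leaves unreadable from compound 3 to compound 4. For compound 4 the estimated value is 100000 nM, with an expected range from 60000 nM to 200000 nM.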

Compound 4, half-maximal inhibitory concentration: > 87000 nM
Compound 4 ended at the assay's limit (the forecaster's own chance of this, stated with the estimate: 85%); the middle value lies beyond the limit too.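

Compound 4 gives > 87000 nM in this assay, which is a limit, so neither the step from compound 3 to compound 4 nor the step from compound 1 to compound 4 can be read: the limit of > 87000 nM in this assay, at which 3 of the 4 values shown sit. The compounds shown leave open whether methoxymethyl in place of hydrogen on the oxygen, or methyl in place of hydrogen on the aromatic carbon, changes activity at all.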